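A few compounds are considered here, and "the series" means these few. Any claim that something is new, unique, unknown or untested is made for them only; others in the source may bear on it.

In an assay on isolated protein for displacement of a labelled ligand from Orexin/Hypocretin receptor type 1 (Homo sapiens), with a stated time of 90 min (a higher number here means a weaker inhibitor, a lower number a stronger inhibitor), compound 2 `COc1cc(N2C(=O)N(Cc3c(F)cc(F)cc3F)c3ccccc3S2(=O)=O)cc(OC)n1` gives 15.9 nM, the lowest of the two numbers in hand. For the measured compounds named here, compound 1 `COc1ccc(N2C(=O)N(Cc3c(F)cc(F)cc3F)c3ccccc3S2(=O)=O)cc1OC` gives 50.1 nM, and the step of a 3.2-fold lower number from compound 1 to compound 2 (0.50 log units; beyond the scatter) is the only measured step. Compound 3 `COc1cc(N2C(=O)N(Cc3c(F)cc(F)cc3F)c3ccccc3S2(=O)=O)ccn1` differs from compound 2 by hydrogen in place of methoxy on an aromatic carbon. Going by the values given here, the one measured step replaced the whole aryl group, so it speaks only loosely to removing a single methoxy; nothing in hand isolates that group. Compound 3 is therefore expected to change little, by a 1.6-fold higher number from compound 2 to compound 3 (0.20 log units; within the scatter). The estimate for compound 3 is 25 nM, ranging from 10 nM to 63 nM.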

Compound 3, inhibition constant: 398 nM
Compound 3: the middle estimate sits 16-fold (1.20 log units) below what was measured, and the stated range ends below it.
By their numbers in this assay, from the lowest: compound 2; then compound 1; then compound 3.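

Taking this one methoxy off the ring, at the carbon next to the ring nitrogen, has a far larger effect than the earlier swap of the whole aryl group, with a 25-fold higher number from compound 2 to compound 3 (1.40 log units; beyond the scatter) for a change of only two heavy atoms. The 2-methoxypyridin-4-yl group also does worse than the 3,4-dimethoxyphenyl group, with a 7.9-fold higher number from compound 1 to compound 3 (0.90 log units; beyond the scatter), so a pyridine ring with a single methoxy does not keep the low number of compound 2. Nothing measured here explains why this methoxy matters so much. Going by these compounds, it remains open whether an ethoxy, a methyl, a fluorine or an amine at this carbon would bring the number back down, or whether only methoxy does so.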